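Pyridin-2-yl Replaces the Pyrrole on the Amide Carbonyl

The source may report more compounds than this note shows. Statements on the series, on what has been measured and on what is new or still open speak of the compounds shown alone.

Within the data shown here, compound 2 `COc1cc2nc(N3CCN(C(=O)c4ccc[nH]4)[C@H]4CCCC[C@H]43)nc(N)c2cc1OC` carries the lower of the two numbers measured so far in an assay on CHO cells for displacement of a labelled ligand from Alpha-1D adrenergic receptor (Homo sapiens) (on this read-out lower numbers stand for stronger inhibition and higher numbers for weaker inhibition), where compound 2 gives 1.51 nM. Among the measured compounds shown here, its only neighbour is compound 1 `COc1cc2nc(N3CCN(C(=O)c4cccs4)[C@H]4CCCC[C@H]43)nc(N)c2cc1OC`, which in this assay gives 2.34 nM; the step of a 1.5-fold lower number from compound 1 to compound 2 (0.19 log units; within the scatter) lies within the scatter, so the two compounds cannot be ordered against each other. Compound 3 `COc1cc2nc(N3CCN(C(=O)c4ccccn4)[C@H]4CCCC[C@H]43)nc(N)c2cc1OC` is the next compound to be tested. Its difference from compound 2 is pyridin-2-yl in place of 1H-pyrrol-2-yl on a carbonyl carbon, so the (1H-pyrrol-2-yl)carbonyl becomes a (pyridin-2-yl)carbonyl. For the measured compounds named here, the one measured step that bears on this change is the exchange of thiophen-2-yl for 1H-pyrrol-2-yl at the same carbonyl carbon, a 1.5-fold lower number from compound 1 to compound 2 (0.19 log units; within the scatter), which stayed within the scatter. Two five-membered aromatic rings have thus given numbers close together; a six-membered ring with a hydrogen-bond acceptor in place of a hydrogen-bond donor has not been tested here. Compound 3 is therefore expected to stay close, with an estimated step of a 1.7-fold higher number from compound 2 to compound 3 (0.22 log units; within the scatter). The estimate for compound 3 is 2.5 nM, with a range from 1 nM to 6 nM.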

Compound 3, inhibition constant: 26.9 nM
The estimate for compound 3 lay 11-fold (1.03 log units) below the measured number; the measured number lies above the stated range.
By their numbers in this assay, from the lowest: compounds 2 and 1 (each within the scatter of the next); then compound 3.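

In this assay the ring on this carbonyl carbon turns out to matter: pyridin-2-yl in place of 1H-pyrrol-2-yl gives an 18-fold higher number from compound 2 to compound 3 (1.25 log units; beyond the scatter) and pyridin-2-yl in place of thiophen-2-yl gives an 11-fold higher number from compound 1 to compound 3 (1.06 log units; beyond the scatter) and both steps lie beyond the scatter. The earlier pair, with its two five-membered aromatic rings, had shown no such sensitivity, since compound 1 and compound 2 could not be ordered against each other. The rise in the number appears against both five-membered partners, so it does not rest on one of them alone, and nothing measured here gives a reason for it.

The step to compound 3 changes ring size and exchanges a hydrogen-bond donor for a hydrogen-bond acceptor in a single move, so the compounds shown cannot say which of these goes with the higher number. Going by these compounds, it also stays open whether a phenyl ring, which would keep the six-membered size without the ring nitrogen, or a small alkyl group such as methyl on the same carbonyl carbon would sit with compound 1 and compound 2 or with compound 3.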